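A few compounds are considered here, and "the series" means these few. Any claim that something is new, unique, unknown or untested is made for them only; others in the source may bear on it.

Compound 3, `Fc1cccc(COc2ccc(-c3cc(CN4CCN(Cc5ccc(C(F)(F)F)cc5)CC4)no3)cc2)c1`, gives the lowest number of the three compounds measured in a functional assay on Mahlavu cells (Homo sapiens) for antiproliferative activity, read by sulforhodamine B assay, with a stated time of 72 h; on this read-out lower numbers stand for stronger inhibition and higher numbers for weaker inhibition: compound 3 shows 2900 nM. Compound 1, `Cc1ccc(COc2ccc(-c3cc(CN4CCN(Cc5ccc(C(F)(F)F)cc5)CC4)no3)cc2)cc1`, shows 7500 nM, and compound 2, `N#Cc1cccc(COc2ccc(-c3cc(CN4CCN(Cc5ccc(C(F)(F)F)cc5)CC4)no3)cc2)c1`, shows 10600 nM. The step from compound 1 to compound 3 was a 2.6-fold lower number from compound 1 to compound 3 (0.41 log units; beyond the scatter), and that from compound 2 to compound 3 was a 3.7-fold lower number from compound 2 to compound 3 (0.56 log units; beyond the scatter), so the fluoro-bearing benzyl ether sits beyond the scatter from both its neighbours.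

Compound 4, `COc1cccc(COc2ccc(-c3cc(CN4CCN(Cc5ccc(C(F)(F)F)cc5)CC4)no3)cc2)c1`, differs from compound 3 in one place: methoxy in place of fluoro on an aromatic carbon. Among the measured compounds shown here, no measured pair swaps fluoro for methoxy, so the two steps into compound 3 only show that exchanging the substituent on this ring has moved this assay by modest amounts, and that the fluoro group gave the lowest number so far. A methoxy group is therefore expected to give a modestly higher number, toward the values of compounds 1 and 2. Compound 4 is estimated at 5000 nM, in a range from 2000 nM to 12000 nM, which corresponds to an expected step of a 1.7-fold higher number from compound 3 to compound 4 (0.24 log units; within the scatter).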

Compound 4, half-maximal inhibitory concentration: 1400 nM
Estimate against measurement, compound 4: 3.6-fold (0.55 log units) above; measured number outside the range, below it.
By their numbers in this assay, from the lowest: compound 4; then compound 3; then compounds 1 and 2 (each within the scatter of the next).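

In this assay the exchange of fluoro for methoxy on this ring goes further down rather than back up (a 2.1-fold lower number from compound 3 to compound 4 (0.32 log units; beyond the scatter)), so compound 4 now holds the lowest number of the four. The distance from the other two substituted benzyl ethers is larger still (a 7.6-fold lower number from compound 2 to compound 4 (0.88 log units; beyond the scatter); a 5.4-fold lower number from compound 1 to compound 4 (0.73 log units; beyond the scatter)), which shows that changes on this ring span a wider range in this assay than the first three compounds revealed. Nothing measured here accounts for the order of these groups.

The compounds shown leave open whether the lower number is particular to methoxy or would also appear with an ethoxy, hydroxyl or dimethylamino group in the same place. They also leave open whether this step would keep its size if a chloro group replaced the trifluoromethyl group elsewhere in the molecule.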